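The source may report more compounds than this note shows. Statements on the series, on what has been measured and on what is new or still open speak of the compounds shown alone.

Compound 1 `CCCCCCCCS(=O)(=O)Nc1cc(CCc2ccccc2)ccc1C(=O)O` and compound 3 `CCCCCCCCS(=O)(=O)Nc1ccc(CCc2ccccc2)cc1C(=O)O` are built from the same atoms joined differently; the difference between the two cores is not broken down here. In an assay on mitochondria (strain BALB/c) for inhibition of glycerol-3-phosphate acyltransferase 1, mitochondrial (Mus musculus), read by scintillation counting, with a stated time of 10 min (a lower number here means a stronger inhibitor, a higher number a weaker inhibitor), compound 1 gives 37500 nM and compound 3 gives 37500 nM. Compound 2 `CCCCCCCCS(=O)(=O)Nc1cc(CCc2ccc(OC)cc2)ccc1C(=O)O` is compound 1 carrying the change (methoxy in place of hydrogen on an aromatic carbon). In this assay compound 2 gives 43000 nM, and the step of a 1.1-fold higher number from compound 1 to compound 2 (0.06 log units; within the scatter) lies within the scatter. Compound 4 `CCCCCCCCS(=O)(=O)Nc1ccc(CCc2ccc(OC)cc2)cc1C(=O)O` has not yet been measured; it is compound 3 carrying the same change, (methoxy in place of hydrogen on an aromatic carbon). Because the step of a 1.1-fold higher number from compound 1 to compound 2 (0.06 log units; within the scatter) stayed within the scatter, compound 4 is expected to give a number in this assay close to that of its parent, an expected step of a 1.1-fold higher number from compound 3 to compound 4 (0.05 log units; within the scatter). Compound 4 is therefore estimated at 42000 nM, most likely between 24000 nM and 75000 nM.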

Compound 4, half-maximal inhibitory concentration: 26300 nM
Beside the measured number, compound 4's estimate is 1.6-fold (0.20 log units) above it; the range from low to high includes it.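

The same methoxy change on the second core gives a 1.4-fold lower number from compound 3 to compound 4 (0.15 log units; within the scatter) in this assay, and the two steps do not differ measurably: the same change on two cores in this assay, a 1.1-fold higher number (0.06 log units; within the scatter) from compound 1 to compound 2 and a 1.4-fold lower number (0.15 log units; within the scatter) from compound 3 to compound 4, 1.6-fold (0.21 log units) apart, within the scatter of two such steps. On both cores, then, putting methoxy in place of hydrogen leaves the number within the scatter, so in these two pairs the change carries over as a step too small to read. This does not show that the cores respond identically, as steps this small could hide a real difference, and it says nothing about changes that move the number further.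

As far as these compounds go, it remains open whether another group at the same place, such as an amine, a hydroxyl or a fluorine, would give a step beyond the scatter on either core.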